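Benzyl-type ether replacements on the shared core

A few compounds are considered here, and "the series" means these few. Any claim that something is new, unique, unknown or untested is made for them only; others in the source may bear on it.

Measured so far in a functional assay on A-375 cells (Homo sapiens) for antiproliferative activity, read by MTT assay, with a stated time of 24 h; on this read-out lower numbers stand for stronger inhibition and higher numbers for weaker inhibition:
compound 1 `COc1cc(OC)c(-c2coc3cc(OCC=C(C)C)ccc3c2=O)cc1OC` gives 1580 nM
compound 2 `COc1cc(OC)c(-c2coc3cc(OCc4ccccc4)ccc3c2=O)cc1OC` gives 1640 nM
compound 3 `COc1cc(OC)c(-c2coc3cc(OCc4ccc(Br)cc4)ccc3c2=O)cc1OC` gives 1000 nM

Compound 1 stands second highest of the three numbers. Its nearest neighbour is compound 2, with a 1.0-fold higher number from compound 1 to compound 2 (0.02 log units; within the scatter); its furthest is compound 3, with a 1.6-fold lower number from compound 1 to compound 3 (0.20 log units; within the scatter). The remaining pair shows a 1.6-fold lower number from compound 2 to compound 3 (0.21 log units; within the scatter). All three numbers therefore sit within the usual scatter of one another, and no ordering among them can be read.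

Compound 4 `COc1cc(OC)c(-c2coc3cc(OCc4cccc(C(F)(F)F)c4)ccc3c2=O)cc1OC` differs from compound 1 in one place: 3-(trifluoromethyl)phenyl in place of 2-methylprop-1-en-1-yl on a saturated chain carbon bound to an oxygen on an aromatic ring. The two measured steps that bear on this change are the ones from compound 1 to compound 2 and from compound 1 to compound 3, where the same 2-methylprop-1-en-1-yl group is replaced by phenyl or by 4-bromophenyl; both lie within the scatter. On that basis no step beyond the scatter is expected, and compound 4 is estimated to show a 1.3-fold lower number from compound 1 to compound 4 (0.12 log units; within the scatter). Compound 4 is expected to give 1200 nM in this assay, with a range of 550 nM to 2600 nM.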

Compound 4, half-maximal inhibitory concentration: 1140 nM
Estimate against measurement, compound 4: 1.1-fold (0.02 log units) above, within the range that was stated.
By their numbers in this assay, from the lowest: compounds 3, 4, 1 and 2 (each within the scatter of the next).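

In this assay, a second substituted benzyl ether also stays within the scatter of the 3-methylbut-2-en-1-yl ether, with a 1.4-fold lower number from compound 1 to compound 4 (0.14 log units; within the scatter). Adding a trifluoromethyl group to the phenyl group gives a 1.4-fold lower number from compound 2 to compound 4 (0.16 log units; within the scatter), and 3-(trifluoromethyl)phenyl in place of 4-bromophenyl gives a 1.1-fold higher number from compound 3 to compound 4 (0.06 log units; within the scatter), so neither change to the phenyl group separates compound 4 from its neighbours. No measurement here bears on why these numbers stay together.

Still open, from the compounds shown here alone, is whether an amine, a carboxylic acid or a longer chain on this saturated chain carbon would produce a step beyond the scatter. Also open, going by these compounds, is how a free hydroxyl in place of the whole ether on the shared core would compare with these four compounds.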